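This account rests on a few compounds, and the source may have more. Where it says the series, first, only, none or still open, it means among the compounds named here.

Measured compounds:
compound 1 `CCCc1ccsc1CN[C@@H]1C[C@H]2C[C@@H]([C@H]1C)C2(C)C`: 50000 nM
compound 2 `C[C@H]1[C@H](NCc2cnccn2)C[C@H]2C[C@@H]1C2(C)C`: > 100000 nM (a limit of the assay)
compound 3 `C[C@H]1[C@H](NCc2ccoc2)C[C@H]2C[C@@H]1C2(C)C`: > 100000 nM (a limit of the assay)

Within the data shown here, in an ADME assay on MDCK cells (Canis lupus familiaris) for cytotoxicity, read by microscopy, with a stated time of 48 h (on this read-out higher numbers stand for lower toxicity in this test and lower numbers for higher toxicity in this test), compound 1 stands as the only compound with a number, at 50000 nM. Compound 2 reaches only a limit of the assay, > 100000 nM. Compound 3 likewise reaches only a limit, > 100000 nM, so that two of the three readings sit at the limit of > 100000 nM in this assay, at which 2 of the 3 values shown sit. Among the measured compounds shown here, the one step between measured compounds, a step that the two limits leave unreadable from compound 2 to compound 3, is therefore unreadable.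

Compound 4 `CCOc1ccsc1CN[C@@H]1C[C@H]2C[C@@H]([C@H]1C)C2(C)C` differs from compound 1 by ethoxy in place of propyl on an aromatic carbon. For the measured compounds named here, no measured step touches the propyl or an ethoxy group on the ring, so none bears on this change, and the unreadable step from compound 2 to compound 3 gives no direction either. The expected step is therefore a 1.4-fold higher number from compound 1 to compound 4 (0.15 log units; within the scatter), within the usual scatter. Compound 4 is estimated at 70000 nM, with a range from 25000 nM to 200000 nM, and a fair chance that the assay again reports only a limit.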

Compound 4, minimum cytotoxic concentration: 50000 nM
Estimate against measurement, compound 4: 1.4-fold (0.15 log units) above; the range from low to high includes it.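

Putting ethoxy in place of propyl on this aromatic carbon of the five-membered aromatic ring with 1 sulfur gives no change at the digits printed from compound 1 to compound 4 (within the scatter) in this assay, the only readable step among the compounds shown. The earlier compounds shown here gave no reading of any change at this position, and this one shows that a chain carrying 1 hydrogen-bond acceptor and a chain carrying none, each of 3 heavy atoms, read alike here. Nothing shown explains why the two groups read alike.

The compounds shown leave open whether an amine, a carboxylic acid or a longer chain such as butyl on this carbon would also read alike. They also leave open whether the same exchange would read alike on a different core.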